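Furan-3-yl series: replacing methylamino with methyl

The source may report more compounds than this note shows. Statements on the series, on what has been measured and on what is new or still open speak of the compounds shown alone.

Measured so far in an ADME assay on MRC5 cells (Homo sapiens), read by MTT assay, with a stated time of 72 h (on this read-out lower numbers stand for stronger inhibition and higher numbers for weaker inhibition), as the read-out:
- compound 1 `CNc1ncnc2c1c(-c1ccoc1)cn2[C@@H]1O[C@H](CO)[C@@H](O)[C@H]1O`: > 100000 nM (a limit of the assay)
- compound 2 `CNc1ncnc2c1c(-c1cc3ccccc3o1)cn2[C@@H]1O[C@H](CO)[C@@H](O)[C@H]1O`: 75300 nM (a number)

Compound 1 stands only at the limit of > 100000 nM in this assay, at which 1 of the 2 values shown sits, and has no exact number. Compound 3 `Cc1ncnc2c1c(-c1ccoc1)cn2[C@@H]1O[C@H](CO)[C@@H](O)[C@H]1O` keeps the furan-3-yl group of compound 1 but has methyl in place of methylamino on an aromatic carbon. Going by the values given here, the one measured step (an at least 1.3-fold lower number from compound 1 to compound 2 (0.12 log units; that floor lies within the scatter)) replaces a different group, and no measured step touches methylamino. That step therefore offers only weak guidance, and its floor gives no firm size to carry over. A moderate move towards a lower number is expected in this assay, with a return at the limit still possible. The estimated step is (an at least 2.2-fold lower number from compound 1 to compound 3 (0.34 log units; beyond the scatter)). Compound 3 is estimated at 45000 nM (expected range 8000 nM to 100000 nM).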

Compound 3, half-maximal inhibitory concentration: 98300 nM
For compound 3 the middle estimate is 2.2-fold (0.34 log units) below the measured one, within the range that was stated.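

In this assay, methyl on the aromatic carbon next to the ring nitrogen, in place of methylamino, leaves compound 3 with a true number of 98300 nM. The step at this position reads an at least 1.0-fold lower number from compound 1 to compound 3 (0.00 log units; that floor lies within the scatter), so losing the hydrogen-bond donor and acceptor counted for methylamino gives no firm change here. Compound 1 itself holds only a limit and no number: the limit of > 100000 nM in this assay, at which 1 of the 3 values shown sits.

Going by these compounds, whether methyl in place of methylamino reads the same alongside the 1-benzofuran-2-yl group of compound 2 stays open, as does the true size of the step. On these data alone, how a dimethylamino group, a methoxy group or a longer chain such as ethyl would read at this carbon also remains open.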